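Adding a chloro group to the allyloxy compound

The source may hold more compounds than are shown below. What is called first, only, known or untested is meant among the compounds shown, and "the series" means these compounds.

Measured in a functional assay on IMR-32 cells (Homo sapiens) for cytotoxicity, read by sulforhodamine B assay, with a stated time of 48 h; a higher number here means a weaker inhibitor, a lower number a stronger inhibitor:
- compound 1 `O=C(c1cccnc1)c1cc(Cl)cc(Cl)c1O`: 28800 nM
- compound 2 `C=CCOc1ccc(Cl)cc1C(=O)c1cccnc1`: 91000 nM

Compound 2 stands at the higher end of the two numbers, at 91000 nM. Compound 1 gives 28800 nM, and this gap lies beyond the usual scatter. Both compounds are weak inhibitors on these numbers.

Compound 3 `C=CCOc1c(Cl)cc(Cl)cc1C(=O)c1cccnc1` is compound 2 with chloro in place of hydrogen on an aromatic carbon, ortho to an allyloxy group: chloro in place of hydrogen on an aromatic carbon. For the measured compounds named here, no measured pair isolates this change, so the data give no direct size for it. A modest move toward a lower number in this assay is expected, and a result within the scatter of compound 2 would not be surprising. The expected shift is a 1.7-fold lower number from compound 2 to compound 3 (0.22 log units; within the scatter). The estimate for compound 3 is 55000 nM, with an expected range of 22000 nM to 130000 nM.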

Compound 3, half-maximal inhibitory concentration: 52000 nM
Beside the measured number, compound 3's estimate is 1.1-fold (0.02 log units) above it; low and high end bracket the measured number.
By their numbers in this assay, from the lowest: compounds 1, 3 and 2 (each within the scatter of the next, the first and the last beyond it).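

In this assay, for the compounds shown here, chloro in place of hydrogen on the aromatic carbon ortho to an allyloxy group gives a step that stays within the scatter (a 1.8-fold lower number from compound 2 to compound 3 (0.24 log units; within the scatter)), so the change has a measured size at this position for the first time. Allyl in place of hydrogen on the oxygen on the aromatic ring also stays within the scatter (a 1.8-fold higher number from compound 1 to compound 3 (0.26 log units; within the scatter)), which means that, with both chloro groups present, the two groups on that oxygen cannot be told apart in this assay. No further data bear on the reason for either step.

Still open, from the compounds shown here alone, is whether a group other than chloro at this position, such as bromo or an amine, would give a step beyond the scatter. A longer chain or a carboxylic acid on the oxygen in place of allyl is equally untested by the compounds shown.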